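The source may hold more compounds than are shown below. What is called first, only, known or untested is meant among the compounds shown, and "the series" means these compounds.

The measured compounds and their numbers:
Compound 1, `N#C[Se]c1ccc(NC(=O)OCc2ccc([N+](=O)[O-])cc2)cc1`, gives 47100 nM in a functional assay on HT-29 cells (Homo sapiens) for cytotoxicity, read by MTT assay, with a stated time of 72 h; a higher number here means a weaker inhibitor of growth, a lower number a stronger inhibitor of growth.
Compound 2, `N#C[Se]c1ccc(NC(=O)Oc2ccc(F)cc2)cc1`, gives 37600 nM in this assay.
Compound 3, `N#C[Se]c1ccc(NC(=O)OCc2ccccc2)cc1`, gives 41200 nM in this assay.

Compound 3 has the second highest of the three numbers, but all three lie within the usual scatter of one another, so no order among them can be read. Compound 4, `CCCCOC(=O)Nc1ccc([Se]C#N)cc1`, differs from compound 3 by a single change: propyl in place of phenyl on a saturated chain carbon bound to an oxygen next to a carbonyl group. Among the compounds with values here, the one measured single-change step, a 1.1-fold lower number from compound 1 to compound 3 (0.06 log units; within the scatter), concerns a group on an aromatic carbon and not the chain bound to the oxygen, and compound 2 beside compound 3 likewise shows no gap beyond the scatter. Nothing measured speaks directly to propyl in place of phenyl. Compound 4 is therefore expected to stay close to compound 3, a step of a 1.1-fold higher number from compound 3 to compound 4 (0.04 log units; within the scatter). The estimate for compound 4 in this assay is 45000 nM, with a range from 20000 nM to 100000 nM.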

Compound 4, concentration for total growth inhibition: 31300 nM
Beside the measured number, compound 4's estimate is 1.4-fold (0.16 log units) above it; the measured number falls inside the stated range.
By their numbers in this assay, from the lowest: compounds 4, 2, 3 and 1 (each within the scatter of the next).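

At this position, on a saturated chain carbon bound to an oxygen next to a carbonyl group, an aromatic ring can give way to an open chain: in this assay propyl in place of phenyl gives a 1.3-fold lower number from compound 3 to compound 4 (0.12 log units; within the scatter) and stays within the scatter. The earlier step concerned a group on an aromatic carbon, so it could not show this. No evidence available here explains the result. Going by these compounds, whether a longer chain, an amine or a carboxylic acid at this place would also stay within the scatter remains open.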